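From 4-ethylphenyl to phenethyl on a sulfur

The compounds below may be only part of what the source reports. "The series", "measured", "known", "first", "only" and "open" are said of these compounds alone.

In a functional assay on A-375 cells (Homo sapiens) for antiproliferative activity, read by CCK-8 assay, with a stated time of 72 h (on this read-out higher numbers stand for weaker inhibition and lower numbers for stronger inhibition), compound 1 (`CCc1ccc(SCc2ccc(C(=O)Nc3ccccc3N)cc2)cc1`) gives 2420 nM and holds the lower of the two numbers available. In this assay compound 3 (`Nc1ccccc1NC(=O)/C=C/c1ccc(CSCCc2ccccc2)cc1`) gives 15700 nM as its result, a higher number and a gap beyond the usual scatter. Compound 2 (`Nc1ccccc1NC(=O)/C=C/c1ccc(CSc2cccc3ccccc23)cc1`) adds no number, its entry reading "not determined" (no result reported) in the record. Compound 4 (`Nc1ccccc1NC(=O)c1ccc(CSCCc2ccccc2)cc1`) awaits measurement. The change phenethyl in place of 4-ethylphenyl on a sulfur puts phenethyl in place of 4-ethylphenyl on a sulfur and keeps the same atoms, joined differently. For the measured compounds named here, no measured pair isolates this change. Going by the values given here, the only guide is compound 3, which also carries phenethyl on a sulfur and shows 15700 nM as its result, although it differs from compound 4 elsewhere. A moderate move toward weaker inhibition is therefore expected, with the estimated step of a 2.5-fold higher number from compound 1 to compound 4 (0.39 log units; beyond the scatter) pointing to a higher number. The estimate for compound 4 is 6000 nM within an expected range of 1800 nM to 20000 nM on this read-out.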

Compound 4, half-maximal inhibitory concentration: 2860 nM
Compound 4: middle estimate off by 2.1-fold (0.32 log units), on the high side, and the stated range covers the measured number.
By their numbers in this assay, from the lowest: compounds 1 and 4 (each within the scatter of the next); then compound 3.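

In this assay this position gets its first direct reading: a 1.2-fold higher number from compound 1 to compound 4 (0.07 log units; within the scatter), so phenethyl in place of 4-ethylphenyl on a sulfur leaves the number unmoved, even though the same atoms are joined differently. Phenethyl on a sulfur therefore does not by itself bring the higher number of compound 3 at 15700 nM in this assay. Nothing available gives a reason why the two groups read alike here.

The compounds shown leave open whether this tolerance reaches beyond these two groups of equal size, for instance to a longer chain on the sulfur or to a carboxylic acid or an amine on the aromatic ring of phenethyl. They also leave open whether the same swap would read alike on a different core.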